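The source may hold more compounds than are shown below. What is called first, only, known or untested is meant among the compounds shown, and "the series" means these compounds.

Measured compounds:
- compound 1, `O=C1O[C@H]([C@@H](O)Cn2cc(CCO)nn2)C(OCc2ccccc2)=C1OCc1ccccc1`: > 100000 nM
- compound 2, `COc1ccccc1-c1cn(C[C@H](O)[C@H]2OC(=O)C(OCc3ccccc3)=C2OCc2ccccc2)nn1`: > 100000 nM
- compound 3, `Cc1ccc(-c2cn(C[C@H](O)[C@H]3OC(=O)C(OCc4ccccc4)=C3OCc3ccccc3)nn2)cc1`: > 100000 nM

In a functional assay on CFPAC-1 cells (Homo sapiens) for antiproliferative activity, read by MTT assay, with a stated time of 72 h (on this read-out higher numbers stand for weaker inhibition and lower numbers for stronger inhibition), compound 3 gives > 100000 nM, which is a limit of the assay and not a number. Compound 1 likewise gives only a limit, > 100000 nM in this assay. Compound 2 also stops at a limit, > 100000 nM. Since all three values sit at the same limit, (the limit of > 100000 nM in this assay, at which 3 of the 3 values shown sit), the three measured steps cannot be read: a step that the two limits leave unreadable from compound 1 to compound 2, a step that the two limits leave unreadable from compound 1 to compound 3 and a step that the two limits leave unreadable from compound 2 to compound 3 have no readable size.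

Compound 4, `CCCCCCCCCCc1cn(C[C@H](O)[C@H]2OC(=O)C(OCc3ccccc3)=C2OCc2ccccc2)nn1`, has not yet been measured in this assay. It differs from compound 3 in one place: decyl in place of 4-methylphenyl on an aromatic carbon. For the measured compounds named here, none of the measured steps touches a decyl chain, and none of them has a readable size, so no step in this assay can be anticipated from them in either direction. The expectation for compound 4 therefore rests on the limit shared by all three measured compounds, and is that compound 4 is estimated to show a step of a number no higher from compound 3 to compound 4 (the limit leaves the size open). Compound 4 is thus expected to give about 100000 nM, with a range from 20000 nM to 300000 nM, and most likely only a limit again.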

Compound 4, half-maximal inhibitory concentration: 40300 nM
Estimate against measurement, compound 4: 2.5-fold (0.39 log units) above; the range from low to high includes it.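

In this assay, compound 4 is the first compound shown to give a number and not a limit, so a change at this aromatic carbon of the five-membered ring can move the read-out, whereas the steps among compound 1, compound 2 and compound 3 cannot be read. Decyl in place of 4-methylphenyl gives an at least 2.4-fold lower number from compound 3 to compound 4 (0.39 log units; beyond the scatter), decyl in place of 2-methoxyphenyl gives an at least 2.4-fold lower number from compound 2 to compound 4 (0.39 log units; beyond the scatter), and decyl in place of 2-hydroxyethyl gives an at least 2.4-fold lower number from compound 1 to compound 4 (0.39 log units; beyond the scatter). These steps set only a minimum size because the other three values are not numbers: the limit of > 100000 nM in this assay, at which 3 of the 4 values shown sit.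

With a single chain that gives a number, the compounds shown do not tell how the read-out follows chain length, for example with a hexyl or a dodecyl chain. They also leave open whether an amine or a carboxylic acid at the end of the decyl chain would keep the step.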